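The compounds below may be only part of what the source reports. "The series", "measured", "known", "first", "only" and "open" are said of these compounds alone.

Measured in a functional assay on KB cells (Homo sapiens) for cytotoxicity, read by MTT assay, with a stated time of 72 h; on this read-out lower numbers stand for stronger inhibition and higher numbers for weaker inhibition:
- compound 1 `O=S(=O)(c1ccc(Br)cc1)c1nc2ccccc2nc1Nc1ccccc1`: 5100 nM
- compound 2 `COc1ccc(Nc2nc3ccccc3nc2S(=O)(=O)c2ccc(Br)cc2)cc1`: "not determined" (no result reported)
- compound 3 `COc1cc(Nc2nc3ccccc3nc2S(=O)(=O)c2ccc(Br)cc2)cc(OC)c1`: "not determined" (no result reported)

Compound 3 has no place on the numeric scale, since no single number stands for it in this assay. For the measured compounds named here, compound 2 shares that gap, which leaves compound 1 as the only compound with a number. Going by the values given here, no comparison of potency can therefore be drawn among the three, and no step between measured compounds is available to show how this series responds to a change of substituent.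

The next compound to be read is compound 4 `Nc1cccc(Nc2nc3ccccc3nc2S(=O)(=O)c2ccc(Br)cc2)c1`. Its structural change is 3-aminophenyl in place of 3,5-dimethoxyphenyl on a nitrogen on an aromatic ring. The missing number for compound 3 means that the size of this step cannot be stated directly. The expectation therefore rests on compound 1 at 5100 nM as the sole anchor. In this assay, compound 4 is expected to lie near that anchor, with no step beyond the scatter and no preferred direction. The range is kept wide, as one number is thin support.

For compound 4 the estimated value is 4000 nM, with an expected range from 1000 nM to 16000 nM.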

Compound 4, half-maximal inhibitory concentration: 5340 nM
Compound 4: the middle estimate sits 1.3-fold (0.13 log units) below what was measured; low and high end bracket the measured number.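

In this assay the series gains its first readable step, a 1.0-fold higher number from compound 1 to compound 4 (0.02 log units; within the scatter), for amino in place of hydrogen on an aromatic carbon. This shows that, on the ring carried by the nitrogen, the 3-aminophenyl group gives a read-out that cannot be told apart from that of the hydrogen-bearing parent, so adding this one group to the shared core leaves the cytotoxicity reading where it was. The steps that involve compound 2 or compound 3 cannot be read, so the exchange of 3,5-dimethoxyphenyl for 3-aminophenyl has no size, and nothing measured here explains the flat step.

Going by these compounds, it remains open whether this aromatic carbon stays as flat with a different group there, such as a carboxylic acid, a hydroxyl or an acetamide, since one amino group is a single probe of the position. Also open, on these data alone, is how far the methoxy groups of compound 2 and compound 3 would move the read-out relative to compound 1 and compound 4 on the same scale.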